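A few compounds are considered here, and "the series" means these few. Any claim that something is new, unique, unknown or untested is made for them only; others in the source may bear on it.

Of the compounds shown here, three sharing one core have been measured in a functional assay on A-431 cells (Homo sapiens) for inhibition, read by MTT assay, with a stated time of 72 h; on this read-out lower numbers stand for stronger inhibition and higher numbers for weaker inhibition. Compound 1 `CC/C=C/C(=O)Nc1cccc(Oc2nc(Nc3cccc(OC)c3)nc3ccsc23)c1` gives 29200 nM. Compound 2 `C=CC(=O)Nc1cccc(Oc2nc(Nc3cccc(C#N)c3)nc3ccsc23)c1` gives 3790 nM. Compound 3 `C/C=C/C(=O)Nc1cccc(Oc2nc(Nc3cccc(C#N)c3)nc3ccsc23)c1` gives 20100 nM, the second highest of the three numbers; it lies within the scatter of compound 1 and beyond the scatter from compound 2. Going by the values given here, the only step that bears on chain lengthening is a 5.3-fold higher number from compound 2 to compound 3 (0.72 log units; beyond the scatter). Compound 4 `CC/C=C/C(=O)Nc1cccc(Oc2nc(Nc3cccc(C#N)c3)nc3ccsc23)c1` carries the change (methyl in place of hydrogen on a saturated chain carbon bound to a double-bonded chain carbon), extending the chain once more. Among the compounds with values here, no measured step isolates this change, but compound 1, which also carries but-1-en-1-yl, shows a number close to that of compound 3. A small rise, or none beyond the scatter, is therefore expected in this assay. Compound 4 is expected at 30000 nM, between 12000 nM and 75000 nM, an expected step of a 1.5-fold higher number from compound 3 to compound 4 (0.17 log units; within the scatter).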

Compound 4, half-maximal inhibitory concentration: 36200 nM
Estimate against measurement, compound 4: 1.2-fold (0.08 log units) below; low and high end bracket the measured number.
By their numbers in this assay, from the lowest: compound 2; then compounds 3, 1 and 4 (each within the scatter of the next).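

In this assay, the further lengthening from prop-1-en-1-yl to but-1-en-1-yl stays within the scatter (a 1.8-fold higher number from compound 3 to compound 4 (0.26 log units; within the scatter)), unlike the first lengthening from vinyl, while the full change from vinyl to but-1-en-1-yl lies beyond it (a 9.6-fold higher number from compound 2 to compound 4 (0.98 log units; beyond the scatter)). With but-1-en-1-yl in place, cyano in place of methoxy on an aromatic carbon also stays within the scatter (a 1.2-fold higher number from compound 1 to compound 4 (0.09 log units; within the scatter)). The compounds shown leave open whether a longer chain, or an amine on a saturated chain carbon bound to a double-bonded chain carbon, would change the number in this assay. No measured evidence here accounts for these numbers.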